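Aryl ureas on an aminoindazole core: the butoxy analogue

The source may report more compounds than this note shows. Statements on the series, on what has been measured and on what is new or still open speak of the compounds shown alone.

Three compounds of the series carry a measured value in a functional assay on A498 cells (Homo sapiens) for inhibition, read by sulforhodamine B assay, with a stated time of 48 h; a higher number here means a weaker inhibitor of growth, a lower number a stronger inhibitor of growth. Compound 1 `O=C(Nc1ccccc1OC(F)(F)F)Nc1n[nH]c2ccccc12` returns only a limit of the assay, > 100000 nM. Compound 3 `COc1ccc(NC(=O)Nc2n[nH]c3ccccc23)cc1` likewise returns only a limit, > 100000 nM. Going by the values given here, compound 2 `Nc1nn(C(=O)Nc2ccc(Cc3ccccc3)cc2)c2ccccc12` is the one member with a number: in this assay compound 2 gives 16700 nM. Among the compounds with values here, compound 2 therefore stands alone below the ceiling, while the two other values shown sit at the limit of > 100000 nM in this assay, at which 2 of the 3 values shown sit; with no pair differing in a single place, no measured step exists to lean on.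

Compound 4 `CCCCOc1ccc(NC(=O)n2nc(N)c3ccccc32)cc1` keeps the core of compound 2 and changes one group: butoxy in place of benzyl on an aromatic carbon, para to a large group. Within the data shown here, the series gives no step of this kind, so the expectation rests on compound 2 alone. With one ring leaving and a short chain entering at the same place, a step in this assay of modest size toward weaker growth inhibition is expected, and one within the scatter cannot be ruled out.

Compound 4 is thus estimated at 25000 nM, between 8000 nM and 100000 nM. The expected step from compound 2 to compound 4 is a 1.5-fold higher number from compound 2 to compound 4 (0.18 log units; within the scatter).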

Compound 4, concentration for 50% growth inhibition: 19000 nM
Compound 4: middle estimate off by 1.3-fold (0.12 log units), on the high side, within the range that was stated.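

In this assay, going by these compounds alone, the exchange gives a 1.1-fold higher number from compound 2 to compound 4 (0.06 log units; within the scatter), the first measured step. At this place, on an aromatic carbon para to a large group, the benzyl ring can therefore give way to an open butoxy chain without a difference beyond the scatter, so in this pair an aromatic ring at this place is not needed for a measured value rather than a limit. Compound 4 is the second member with a number, while compound 1 and compound 3 remain at a limit of the assay, and no steps to them can be read: the limit of > 100000 nM in this assay, at which 2 of the 4 values shown sit.

Whether a longer chain such as hexyloxy, an amine or a carboxylic acid at the same place would move the value beyond the scatter stays open, as the one step shown covers only butoxy and benzyl. A single pair also cannot show whether the same exchange would give a similar result at another place on that ring or on a different core.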